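A few compounds are considered here, and "the series" means these few. Any claim that something is new, unique, unknown or untested is made for them only; others in the source may bear on it.

Values in a functional assay on RAW264.7 cells (Mus musculus) for inhibition, with stated times of 2 h and 24 h; a higher number here means a weaker inhibitor, a lower number a stronger inhibitor:
- Compound 1 `COc1cc(OC)cc([C@@H]2C(=O)c3cc(OC)cc(OC)c3[C@H]2c2ccccc2)c1`: 27100 nM
- Compound 2 `COc1ccc([C@@H]2c3c(OC)cc(OC)cc3C(O)[C@H]2c2cc(OC)cc(OC)c2)cc1`: 7870 nM
- Compound 3 `COc1ccc([C@@H]2c3c(OC)cc(OC)cc3C(SCc3ccc(F)cc3)[C@H]2c2cc(OC)cc(OC)c2)cc1`: > 200000 nM (a limit, not a number)

Compound 3 stands at the limit of > 200000 nM in this assay, at which 1 of the 3 values shown sits, so its place is a limit and not a number.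

Compound 4 `COc1ccc([C@@H]2c3c(OC)cc(OC)cc3C(C(O)c3ccccc3)[C@H]2c2cc(OC)cc(OC)c2)cc1` has hydroxy(phenyl)methyl in place of (4-fluorobenzyl)sulfanyl on a saturated ring carbon.

Among the measured compounds shown here, one measured step bears on this change: an at least 25-fold higher number from compound 2 to compound 3 (1.40 log units; beyond the scatter). That large step, beyond the scatter, came when (4-fluorobenzyl)sulfanyl took the place of hydroxy. Compound 4 loses that same group and carries a hydroxy again, so much of the step may be undone. A large step towards a lower number, meaning a stronger inhibitor, is therefore expected in this assay. The new group is still not the plain hydroxy of compound 2 at 7870 nM, so a full return is not assumed.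

The expected change is an at least 6.6-fold lower number from compound 3 to compound 4 (0.82 log units; beyond the scatter). For compound 4 the estimate is 30000 nM, with an expected range of 8000 nM to 150000 nM.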

Compound 4, half-maximal inhibitory concentration: > 200000 nM
Compound 4 ended at the assay's limit; the forecaster's own chance of this, stated with the estimate: 20%; middle value at least 6.6-fold (0.82 log units) away from the limit.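

In this assay compound 4 gives > 200000 nM, which is a limit of the assay and not a number. Replacing the plain hydroxy with hydroxy(phenyl)methyl on this saturated ring carbon gives an at least 25-fold higher number from compound 2 to compound 4 (1.40 log units; beyond the scatter), so carrying a hydroxy within the larger group does not keep the activity seen with the plain hydroxy, and a loss of this size does not need the sulfur of compound 3. The step between compound 3 and compound 4 cannot be read, because both sit at the same limit: the limit of > 200000 nM in this assay, at which 2 of the 4 values shown sit.

On these data alone, it remains open how far past the limit compound 3 and compound 4 lie. As far as these compounds go, it is also open whether an amine or a carboxylic acid on this carbon would stay close to compound 2 at 7870 nM.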